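The compounds below may be only part of what the source reports. "The series", "measured", "known", "first", "only" and "open" are said of these compounds alone.

In a functional assay on A549 cells (Homo sapiens) for antiproliferative activity, read by MTT assay, with a stated time of 48 h (a higher number here means a weaker inhibitor, a lower number a stronger inhibitor), compound 1 (`COc1ccc(C(=O)c2ccc(OC)c3c2OC(C)(C)C=C3)c(NC(=O)CN)c1`) gives 270 nM and compound 2 (`C=C(c1cc(OC)c(OC)c(OC)c1)c1ccc(OC)cc1NC(=O)CO`) gives 20 nM as the lower of the two numbers, a gap beyond the usual scatter. Compound 3 (`C=C(c1cc(OC)c(OC)c(OC)c1)c1ccc(OC)cc1NC(=O)CN(C)C`) differs from compound 2 at one place (dimethylamino in place of hydroxy on a saturated chain carbon bound to a carbonyl carbon) with dimethylamino in place of hydroxy on a saturated chain carbon bound to a carbonyl carbon. Going by the values given here, no measured pair shows this change alone, so the estimate is uncertain. The expected step (a 2.3-fold higher number from compound 2 to compound 3 (0.35 log units; beyond the scatter)) is a modest weakening. Compound 3 is estimated at 45 nM with a likely range from 10 nM to 200 nM (an expectation, not a measurement).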

Compound 3, half-maximal inhibitory concentration: 130 nM
Compound 3: middle estimate off by 2.9-fold (0.46 log units), on the low side; the measured number falls inside the stated range.
By their numbers in this assay, from the lowest: compound 2; then compound 3; then compound 1.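

Placing dimethylamino in place of hydroxy on a saturated chain carbon bound to a carbonyl carbon moves the number up (a 6.5-fold higher number from compound 2 to compound 3 (0.81 log units; beyond the scatter)) in this assay and shows that this position is sensitive to the group it carries. The change swaps one hydrogen-bond donor for none and adds heavy atoms, and these differences arrive together, so this single step cannot separate them. Nothing available here explains the loss. Going by these compounds, whether methylamino, a carboxylic acid or a longer chain at this place would give a number nearer compound 2 or compound 3 remains open.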